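The source may report more compounds than this note shows. Statements on the series, on what has been measured and on what is new or still open speak of the compounds shown alone.

Of the compounds shown here, two of a shared core have been measured. Compound 1 `CCCCc1nc(N)c2nc(O)n(Cc3ccccc3)c2n1` carries a butyl group on the aromatic carbon in question, and in a functional assay on the whole organism for activation, with Mus musculus as the target (on this read-out lower numbers stand for an effect already at smaller amounts and higher numbers for an effect only at larger amounts of compound), compound 1 gives 0.3 mg/kg. Compound 2 `CCOc1nc(N)c2nc(O)n(Cc3ccccc3)c2n1` carries an ethoxy group at the same place, and in this assay compound 2 gives 0.3 mg/kg. The step between them, no change at the digits printed from compound 1 to compound 2 (within the scatter), shows that exchanging one group for another at this carbon left the read-out where it was. Among the compounds with values here, compound 2 thus stands level with compound 1 at the digits recorded, with no other measured compound to set against it.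

Compound 3 `CCCNc1nc(N)c2nc(O)n(Cc3ccccc3)c2n1` differs from compound 2 in one place: propylamino in place of ethoxy on an aromatic carbon. Within the data shown here, only one measured step bears on this change, the one from compound 1 to compound 2, and that step was flat within the scatter. The entering group differs from both butyl and ethoxy in the counts shown, so the precedent is indirect. On the evidence at hand, a step of no change at the digits printed from compound 2 to compound 3 (within the scatter) is expected, that is, no change beyond the scatter. Compound 3 is estimated to give 0.3 mg/kg in this assay, within a range from 0.1 mg/kg to 1 mg/kg.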

Compound 3, minimum effective dose: 1 mg/kg
For compound 3 the middle estimate is 3.3-fold (0.52 log units) below the measured one, and the stated range covers the measured number.
By their numbers in this assay, from the lowest: compounds 1 and 2 (each within the scatter of the next); then compound 3.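

In this assay, this aromatic carbon proves not to be indifferent to its substituent: propylamino in place of ethoxy gives a 3.3-fold higher number from compound 2 to compound 3 (0.52 log units; beyond the scatter), whereas the earlier exchange of butyl for ethoxy gave no change at the digits printed from compound 1 to compound 2 (within the scatter). Propylamino in place of butyl gives a 3.3-fold higher number from compound 1 to compound 3 (0.52 log units; beyond the scatter), so propylamino separates from both earlier groups, with a larger dose needed for an effect on this read-out. No measurement at hand gives a reason for this shift.

The compounds shown leave open whether the step follows the nitrogen attached to the ring or the length of the chain, as propylamino differs from ethoxy in both: propoxy would keep the oxygen with a propyl chain, and ethylamino would keep the nitrogen with an ethyl chain. Also open, going by these compounds, is what happens at this carbon with a dimethylamino group, which has no amine hydrogen, or with a longer chain on the nitrogen, such as butylamino.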